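The compounds below may be only part of what the source reports. "The series", "measured", "known", "first", "only" and "open" are said of these compounds alone.

Measured compounds:
compound 1, `CC(c1ccc(-c2ccccc2)c(F)c1)c1nnc2n1N=C(c1ccccc1)CS2`, 6700 nM in a functional assay on Huh-7 cells (Homo sapiens) for inhibition, read by sulforhodamine B assay, with a stated time of 72 h; on this read-out higher numbers stand for weaker inhibition and lower numbers for stronger inhibition
compound 2, `CC(c1ccc(-c2ccccc2)c(F)c1)c1nnc2n1N=C(c1ccc(C(F)(F)F)cc1)CS2`, 9400 nM in this assay
compound 3, `CC(c1ccc(-c2ccccc2)c(F)c1)c1nnc2n1N=C(c1ccc(Cl)cc1)CS2`, 3900 nM in this assay

Compound 3 gives the lowest of the three numbers in this assay; its gap to compound 1 is within the scatter, while a 2.4-fold lower number from compound 2 to compound 3 (0.38 log units; beyond the scatter) lies beyond it. Compound 4, `Cc1ccc(C2=Nn3c(nnc3C(C)c3ccc(-c4ccccc4)c(F)c3)SC2)cc1`, differs from compound 3 as follows: methyl in place of chloro on an aromatic carbon. For the measured compounds named here, no measured step swaps chloro for methyl. The steps on the same aromatic carbon are a 1.7-fold lower number from compound 1 to compound 3 (0.24 log units; within the scatter) and a 1.4-fold higher number from compound 1 to compound 2 (0.15 log units; within the scatter), both within the scatter, and the modest 2.4-fold lower number from compound 2 to compound 3 (0.38 log units; beyond the scatter). Changes on this aromatic carbon have so far shifted the number only modestly at most. For compound 4 the expected step is a 1.2-fold higher number from compound 3 to compound 4 (0.09 log units; within the scatter), none beyond the scatter. Compound 4 is estimated at 4800 nM, between 2200 nM and 10500 nM.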

Compound 4, half-maximal inhibitory concentration: 7200 nM
The estimate for compound 4 lay 1.5-fold (0.18 log units) below the measured number; low and high end bracket the measured number.
By their numbers in this assay, from the lowest: compounds 3, 1, 4 and 2 (each within the scatter of the next, the first and the last beyond it).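

Swapping chloro for methyl on this aromatic carbon gives a step within the scatter, seen in a 1.8-fold higher number from compound 3 to compound 4 (0.27 log units; within the scatter) and likewise in a 1.3-fold lower number from compound 2 to compound 4 (0.12 log units; within the scatter) and in a 1.1-fold higher number from compound 1 to compound 4 (0.03 log units; within the scatter) when compared with the other two groups. Methyl therefore cannot be told apart from hydrogen, chloro or trifluoromethyl here, and the step between compound 2 and compound 3 remains the only one beyond the scatter at this position. No supporting data explain this result. Going by these compounds, whether an amine, a carboxylic acid or a longer chain on this carbon would shift the number further remains open.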